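Halogen removal on the fused benzene ring of the core

The compounds below may be only part of what the source reports. "The series", "measured", "known", "first", "only" and "open" are said of these compounds alone.

Compound 2 `O=c1c(C2N=C(c3ccccc3)SS2)coc2ccc(F)cc12` carries a fluoro group on the shared core; in a functional assay on HEp-2 cells (Homo sapiens) for inhibition, read by sulforhodamine B assay, with a stated time of 48 h (a lower number here means a stronger inhibitor, a higher number a weaker inhibitor), compound 2 gives 98600 nM. Among the compounds with values here, this is the higher of the two numbers so far, but its nearest neighbour, compound 1 `O=c1c(C2N=C(c3ccccc3)SS2)coc2ccc(Cl)cc12`, gives 74900 nM in this assay, and the swap from chloro to fluoro, a 1.3-fold higher number from compound 1 to compound 2 (0.12 log units; within the scatter), stays within the scatter, so no order between compound 1 and compound 2 can be read from it.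

Compound 3 `O=c1c(C2N=C(c3ccccc3)SS2)coc2ccccc12` is the unmeasured member. It differs from compound 2 by hydrogen in place of fluoro on an aromatic carbon, on an aromatic carbon of the six-membered carbon-only ring of the fused system. Within the data shown here, no measured pair removes the halogen outright; the only related step is the halogen swap a 1.3-fold higher number from compound 1 to compound 2 (0.12 log units; within the scatter), which was small. That step gives no sign that the substituent at this position moves the number much. For compound 3 a step of about a 1.1-fold lower number from compound 2 to compound 3 (0.04 log units; within the scatter) is therefore expected, in no fixed direction and not beyond the scatter. The estimate for compound 3 in this assay is 90000 nM, with a range from 40000 nM to 200000 nM.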

Compound 3, half-maximal inhibitory concentration: > 100000 nM
Compound 3 ended at the assay's limit; the forecaster's own chance of this, stated with the estimate: 15%; middle value at least 1.1-fold (0.04 log units) away from the limit.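

With hydrogen in place of either halogen on this aromatic carbon, the read-out reaches the ceiling of this assay, which is a limit and not a number: the limit of > 100000 nM in this assay, at which 1 of the 3 values shown sits.

The two steps to compound 3 are therefore floors only, an at least 1.0-fold higher number from compound 2 to compound 3 (0.00 log units; that floor lies within the scatter) and an at least 1.3-fold higher number from compound 1 to compound 3 (0.12 log units; that floor lies within the scatter), and neither floor sets an order among the three compounds. Unlike the closed halogen swap, a 1.3-fold higher number from compound 1 to compound 2 (0.12 log units; within the scatter), the removal of the halogen has a size that is bounded on one side only, so a real loss on removing the halogen is neither shown nor excluded.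

The compounds shown leave open how far the true number of compound 3 lies from the limit, and so whether a halogen on this carbon matters at all in this series. They also leave open how an amine, a methoxy group or a carboxylic acid on the same aromatic carbon of the shared core would read, since all three compounds carry only hydrogen, fluoro or chloro there.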